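A few compounds are considered here, and "the series" means these few. Any claim that something is new, unique, unknown or untested is made for them only; others in the source may bear on it.

Measured so far:
compound 1, `CSCc1cc(C(C)=O)c(O)cc1OCCCCCCC#N`: 64%
compound 2, `CCc1cc(C(C)=O)c(O)cc1OCCCC(C)(C)C#N`: 46%

Both numbers come from an assay on isolated protein for binding affinity to leukotriene B4 receptor 1 (Homo sapiens), tested at 1 uM; a higher number here means more inhibition at the concentration tested (going by the name of the read-out), a lower number less inhibition. Compound 2 stands lowest of the two; compound 1 gives the higher value, and the gap between them lies beyond the scatter. Compound 3, `CCc1cc(C(C)=O)c(O)cc1OCCCCCn1cncn1`, is not yet measured in this assay. It differs from compound 2 in one place: 2-(1H-1,2,4-triazol-1-yl)ethyl in place of 1-cyano-1-methylethyl on a saturated chain carbon, three bonds along the chain from an oxygen on an aromatic ring. Among the compounds with values here, no measured pair covers this exchange, so its size is open. A modest shift in either direction, or none beyond the scatter, is expected; the expected step is a number 4 percentage points higher from compound 2 to compound 3 (within the scatter). Compound 3 is estimated at 50%, between 25% and 75%.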

Compound 3, a percentage reported as inhibition, at one concentration (the size of the read-out at that concentration, not a potency): 30%
Estimate against measurement, compound 3: 20 percentage points above, within the range that was stated.
By their numbers in this assay, from the lowest: compound 3; then compound 2; then compound 1.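

Within the data shown here, the exchange of 1-cyano-1-methylethyl for 2-(1H-1,2,4-triazol-1-yl)ethyl gives a number 16 percentage points lower from compound 2 to compound 3 (beyond the scatter) in this assay, the first single-place step. The read-out at this chain position therefore depends on the group carried there, and this five-membered aromatic ring with 3 hetero atoms does not hold the level of the nitrile-bearing group. Nothing available explains the drop.

Open, as far as these compounds go, is how a carboxylic acid or an amine would read at this position. Also open, from the compounds shown here alone, is whether the step keeps its size on a longer chain.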